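The compounds below may be only part of what the source reports. "The series", "measured", "known", "first", "only" and "open" are said of these compounds alone.

Measured in a functional assay on HFF cells (Homo sapiens) for cytotoxicity (a higher number here means a weaker inhibitor, a lower number a stronger inhibitor), as a half-maximal inhibitory concentration:

Compound 1 `O=C1/C(=C/c2ccccc2F)SC(=S)N1NS(=O)(=O)c1ccccc1` reads > 100000 nM (a limit)
Compound 2 `O=C1/C(=C/c2ccc([N+](=O)[O-])cc2)SC(=S)N1NS(=O)(=O)c1ccccc1` reads > 100000 nM (a limit)

Compound 2 has no exact number of its own. Its reading is a limit, and compound 1 shares it (the limit of > 100000 nM in this assay, at which 2 of the 2 values shown sit).

The next compound is compound 3 `O=C1/C(=C/c2ccc(Br)c(Br)c2)SC(=S)N1NS(=O)(=O)c1ccccc1` and the change is 3,4-dibromophenyl in place of 4-nitrophenyl on a double-bonded chain carbon bound to a double-bonded ring carbon. The rest of the molecule stays as it is.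

Within the data shown here, the one measured step at this place is a step that the two limits leave unreadable from compound 1 to compound 2 and it offers no size to carry over. All that can be used is that both measured compounds sit at the same limit. No step beyond the scatter is therefore expected in this assay and no direction can be given. The expected change is a number no higher from compound 2 to compound 3 (the limit leaves the size open) (an estimate, with a further limit reading quite likely). For compound 3 the estimated value is 100000 nM (expected range 40000 nM to 200000 nM).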

Compound 3, half-maximal inhibitory concentration: > 100000 nM
Compound 3 ended at the assay's limit (the forecaster's own chance of this, stated with the estimate: 70%); the middle value lies on the limit itself.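

No step among compound 1, compound 2 and compound 3 can be read in this assay, since all three readings are limits and not numbers: the limit of > 100000 nM in this assay, at which 3 of the 3 values shown sit.

The compounds shown leave open whether swapping among 2-fluorophenyl, 4-nitrophenyl and 3,4-dibromophenyl changes this cell read-out at all, and at what concentration any of the three compounds would reach half-maximal inhibition.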